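A few compounds are considered here, and "the series" means these few. Any claim that something is new, unique, unknown or untested is made for them only; others in the source may bear on it.

Compound 1 `O=C(CCCCC(CCSC(=O)c1ccccc1)SC(=O)c1ccccc1)Nc1ccccc1Cl`: 3.62%
Compound 2 `O=C(CCCCC(CCSC(=O)c1ccccc1)SC(=O)c1ccccc1)Nc1cccc(Cl)c1`: 10.7%

For the measured compounds named here, in a functional assay on KB cells (Homo sapiens) for inhibition, read by MTT assay, with a stated time of 24 h, tested at 0.1 ug/mL (a higher number here means more inhibition of growth at the concentration tested, a lower number less inhibition of growth), compound 2 gives 10.7%, which lies within the scatter of its only measured neighbour, compound 1. The next structure is compound 3 `O=C(CCCCC(CCSC(=O)c1ccccc1)SC(=O)c1ccccc1)Nc1ccc(Cl)cc1`, reached from compound 2 by one swap: 4-chlorophenyl in place of 3-chlorophenyl on an amide-type nitrogen. Going by the values given here, only one measured step bears on this, a similar swap of 3-chlorophenyl in place of 2-chlorophenyl on an amide-type nitrogen: a number 7.1 percentage points higher from compound 1 to compound 2 (within the scatter). With that single small step as the guide, the expected change is a number 1.7 percentage points lower from compound 2 to compound 3 (within the scatter), so no step beyond the scatter is expected. For compound 3 the estimate is 9%, with an expected range of 1% to 20%.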

Compound 3, percent growth inhibition at one concentration: 17%
Compound 3: the middle estimate sits 8 percentage points below what was measured, and the stated range covers the measured number.
By their numbers in this assay, from the lowest: compounds 1, 2 and 3 (each within the scatter of the next, the first and the last beyond it).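

Within this assay, the change to 4-chlorophenyl on the amide-type nitrogen gives a number 6.3 percentage points higher from compound 2 to compound 3 (within the scatter) and also a number 13.4 percentage points higher from compound 1 to compound 3 (beyond the scatter) as its larger step. For the compounds shown here, this is the first step to clear the scatter, so the 2-chlorophenyl and 4-chlorophenyl compounds can be told apart, while the 3-chlorophenyl compound cannot be separated from either. No measurement here explains that difference. Still open, on these data alone, is what plain phenyl, 4-fluorophenyl or 4-methoxyphenyl would give on the same nitrogen, and so whether chlorine itself matters.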